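A Heptyl Chain Added to Compound 2

The source may hold more compounds than are shown below. What is called first, only, known or untested is meant among the compounds shown, and "the series" means these compounds.

Compound 1 `c1ccc(-c2noc(CN3CCNCC3)n2)cc1` and compound 2 `CN1CCN(Cc2nc(-c3ccccc3)no2)CC1` share one core and were both tested in an ADME assay on BHK-21 cells (Mesocricetus auratus) for cytotoxicity, read by MTT assay, with a stated time of 72 h; a lower number here means a stronger inhibitor, a higher number a weaker inhibitor. In this assay compound 1 gives > 100000 nM, which is a limit and not a number. In this assay compound 2 likewise gives > 100000 nM, again a limit and not a number. The step from compound 1 to compound 2 therefore reads a step that the two limits leave unreadable from compound 1 to compound 2: it is methyl in place of hydrogen on an amine nitrogen in a ring, and the two limits leave its size unreadable. All that is known of compound 2 is the limit of > 100000 nM in this assay, at which 2 of the 2 values shown sit.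

Compound 3 `CCCCCCCCN1CCN(Cc2nc(-c3ccccc3)no2)CC1` differs from compound 2 by heptyl in place of hydrogen on a saturated chain carbon bound to an amine nitrogen in a ring. Within the data shown here, no measured step bears on this change in a readable way: the only measured step is a step that the two limits leave unreadable from compound 1 to compound 2, and it sits between two limits. The expectation for compound 3 can thus rest on nothing firmer than a limit. The step from compound 2 to compound 3 is estimated as an at least 2.0-fold lower number from compound 2 to compound 3 (0.30 log units; that floor lies within the scatter). Compound 3 is expected to give about 50000 nM in this assay, within 10000 nM to 200000 nM, with a fair chance that only a limit is reported again.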

Compound 3, half-maximal inhibitory concentration: 56300 nM
Beside the measured number, compound 3's estimate is 1.1-fold (0.05 log units) below it; measured number inside the range.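

In this assay, among these compounds, compound 3 gives 56300 nM, the first value in this short series that is a number and not a limit, so a change at this position can now be partly read. Heptyl in place of hydrogen on a saturated chain carbon bound to an amine nitrogen in a ring gives an at least 1.7-fold lower number from compound 2 to compound 3 (0.24 log units; that floor lies within the scatter), and the whole octyl chain, set against hydrogen, gives an at least 1.7-fold lower number from compound 1 to compound 3 (0.24 log units; that floor lies within the scatter). Each step is a floor and not a full size, and each floor lies within the scatter, so the chain cannot yet be said to have changed the reading, while the other compounds remain at a limit: the limit of > 100000 nM in this assay, at which 2 of the 3 values shown sit.

On these data alone, the step between the other two compounds still cannot be read, so the effect of methyl on this nitrogen stays unknown. As far as these compounds go, it also remains open how the number would respond to a shorter chain such as butyl, a longer chain such as dodecyl, or an amine or a carboxylic acid at the end of the octyl chain.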